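Compound 3 to compound 4: phenethyl in place of phenyl

This account rests on a few compounds, and the source may have more. Where it says the series, first, only, none or still open, it means among the compounds named here.

In an ADME assay on J774 cells (Mus musculus) for cytotoxicity (a lower number here means that less compound is needed, a higher number that more compound is needed for the effect), compound 3 `COC(=O)c1c[nH]c2cc(OCc3ccccc3)ccc2c1=O` gives 18900 nM as the higher of the two actual numbers in the series. Compound 2 `CCCCc1cc2c(=O)c(CC)c[nH]c2cc1OCCOc1ccccc1` gives 360 nM as the nearest number, a gap beyond the scatter. Compound 1 `COC(=O)c1c[nH]c2cc(OCCOc3ccccc3)c(Cl)cc2c1=O` reaches only a limit of > 20000 nM in this assay and gives no actual number.

Compound 4 `COC(=O)c1c[nH]c2cc(OCCCc3ccccc3)ccc2c1=O` carries phenethyl in place of phenyl on a saturated chain carbon bound to an oxygen on an aromatic ring and otherwise matches compound 3.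

Within the data shown here, no measured pair differs in one place only, so this change has no direct precedent in this assay. Compound 2 at 360 nM shows that much lower numbers occur in the series, but it differs from compound 3 in several places and offers only weak guidance. A small move toward a lower number is expected, possibly not beyond the scatter, and the estimated change is a 1.6-fold lower number from compound 3 to compound 4 (0.20 log units; within the scatter) in this direction. For compound 4 the estimated value is 12000 nM with an expected range from 4000 nM to 20000 nM as the working figure.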

Compound 4, half-maximal effective concentration: 1480 nM
Compound 4: middle estimate off by 8.1-fold (0.91 log units), on the high side; the whole stated range lies above it.
By their numbers in this assay, from the lowest: compound 2; then compound 4; then compound 3. At a limit, above all of these: compound 1.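

In this assay, among these compounds, phenethyl in place of phenyl on a saturated chain carbon bound to an oxygen on an aromatic ring gives a 13-fold lower number from compound 3 to compound 4 (1.11 log units; beyond the scatter) and is the first one-place step. Among the compounds shown here, this position therefore responds strongly to the group it carries, which the earlier compounds, none differing in one place only, could not show. Both groups are carbon only, with no hydrogen-bond donors or acceptors and no net charge, so a step of this size needs no such feature to change.

Going by these compounds, a single step sets no trend, and whether a longer chain or an amine on the phenyl ring would move the number further remains open. Compound 1 stands at a limit rather than a number and gives no firm reference point at the high end: the limit of > 20000 nM in this assay, at which 1 of the 4 values shown sits.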